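Chain shortening on the trimethoxy core of compound 3

A few compounds are considered here, and "the series" means these few. Any claim that something is new, unique, unknown or untested is made for them only; others in the source may bear on it.

Three compounds of this series carry a number in an ADME assay on the whole organism (strain S2) for cytotoxicity, with Drosophila as the target, read by WST assay; a lower number here means that less compound is tolerated, a higher number that more compound is tolerated. Compound 1 `CCCCCC(=O)c1c(O)c(Cl)c(OC)c(Cl)c1O` gives 22500 nM. Compound 2 `CCCCCC(=O)c1c(O)c(Cl)c(O)c(Cl)c1O` gives 102000 nM. Compound 3 `CCCCCCCC(=O)c1c(OC)c(Cl)c(OC)c(Cl)c1OC` gives 51400 nM. Among these three, compound 3 sits above compound 1 by a margin beyond the scatter, while the gap to compound 2 lies within the scatter, so no order between compound 3 and compound 2 can be read from the numbers.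

For the measured compounds named here, the only single-point step measured so far is a 4.5-fold higher number from compound 1 to compound 2 (0.66 log units; beyond the scatter). It concerns an oxygen substituent on the aromatic ring and says nothing about the length of the acyl chain.

Compound 4 `CCCC(=O)c1c(OC)c(Cl)c(OC)c(Cl)c1OC` differs from compound 3 by hydrogen in place of butyl on a saturated chain carbon, three bonds along the chain from a carbonyl carbon. Going by the values given here, no measured pair changes the chain, so there is no direct precedent for the size or direction of this step in this assay. Given that, the expectation for compound 4 is a number close to that of compound 3, with a step of a 1.2-fold higher number from compound 3 to compound 4 (0.07 log units; within the scatter) that is not expected to exceed the scatter. Compound 4 is therefore estimated at 60000 nM, within a range from 25000 nM to 150000 nM.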

Compound 4, half-maximal cytotoxic concentration: 144000 nM
For compound 4 the middle estimate is 2.4-fold (0.38 log units) below the measured one; the range from low to high includes it.
By their numbers in this assay, from the lowest: compound 1; then compounds 3, 2 and 4 (each within the scatter of the next, the first and the last beyond it).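

In this assay, hydrogen in place of butyl on a saturated chain carbon, three bonds along the chain from a carbonyl carbon, gives a 2.8-fold higher number from compound 3 to compound 4 (0.45 log units; beyond the scatter), a modest step in the direction of more compound tolerated. Cut one bond further out, this is the difference heptyl to propyl, and it shows that the acyl chain is a place where the number moves beyond the scatter, which the earlier step on an oxygen substituent of the ring could not show. Nothing at hand gives a reason for this step.

Going by these compounds, with only heptyl and propyl compared on the shared core, the shape of the relation between chain and number stays open, including whether a longer chain, an intermediate butyl or pentyl chain, or a chain ending in an amine or a carboxylic acid would follow the same direction. Also open, on these data alone, is whether the same shortening gives a step of similar size and direction when the ring carries hydroxyl groups in place of methoxy groups, as in compound 2.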